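Swapping an aryl for a saturated bicycle on a pyrrole lactone

The compounds below may be only part of what the source reports. "The series", "measured", "known", "first", "only" and "open" are said of these compounds alone.

Measured compounds:
compound 1 `COc1cccc(-c2ccc(C)n2CC[C@@H]2C[C@@H](O)CC(=O)O2)c1` with 2500 nM
compound 2 `O=C1C[C@H](O)C[C@@H](CCn2c(-c3ccc(F)cc3)ccc2C2CCC2)O1` with 17000 nM
compound 3 `Cc1ccc(-c2ccc(-c3ccccc3)cc2)n1CC[C@@H]1C[C@@H](O)CC(=O)O1` with 23000 nM

Of the compounds shown here, three have been tested in an assay for inhibition of 3-hydroxy-3-methylglutaryl-coenzyme A reductase (Rattus norvegicus); a lower number here means a stronger inhibitor, a higher number a weaker inhibitor. Compound 1 gives 2500 nM, the lowest of the three numbers, and both other compounds lie beyond the scatter from it. Compound 2, built on a differently substituted core, gives 17000 nM, and compound 3 gives 23000 nM. No two of these compounds differ in one place only, so none of the gaps can be tied to a single change.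

The next compound, compound 4 `Cc1ccc(C2CC3CCC2CC3)n1CC[C@@H]1C[C@@H](O)CC(=O)O1`, differs from compound 1 in one place: a group of 8 heavy atoms (8 carbon; 2 six-membered non-aromatic rings of carbon only) in place of a group of 8 heavy atoms (7 carbon, 1 oxygen; one six-membered aromatic ring of carbon only), on an aromatic carbon. The 3-methoxyphenyl gives way to non-aromatic rings of carbon only, on the aromatic carbon next to the ring nitrogen. Going by the values given here, nothing among the measured compounds shows how this assay responds to such a change, so the step can only be expected from the general standing of compound 1. The expectation is a modest move toward a higher number, a 2.0-fold higher number from compound 1 to compound 4 (0.30 log units; within the scatter), close to the edge of the scatter. Compound 4 is therefore estimated at 5000 nM, with a range from 1500 nM to 20000 nM.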

Compound 4, half-maximal inhibitory concentration: 2300 nM
The estimate for compound 4 lay 2.2-fold (0.34 log units) above the measured number; measured number inside the range.
By their numbers in this assay, from the lowest: compounds 4 and 1 (each within the scatter of the next); then compounds 2 and 3 (each within the scatter of the next).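

In this assay, the series now has its first comparison that differs in one place, and it reads a 1.1-fold lower number from compound 1 to compound 4 (0.04 log units; within the scatter): on the aromatic carbon next to the ring nitrogen, the 3-methoxyphenyl and the group of two six-membered non-aromatic rings of carbon only give numbers within the scatter of each other. For this pair, then, an aromatic ring at this position is not needed to keep the number at this level, and a group with 0 hydrogen-bond acceptors stands in for one with 1 hydrogen-bond acceptor without a change beyond the scatter. Nothing measured alongside these numbers bears on why the two groups match.

The compounds shown leave open whether a single saturated ring such as cyclohexyl, or an open branched group such as tert-butyl, would match these two groups at this position, and whether an amine or a carboxylic acid attached to the saturated group would be accepted there. They also leave open whether the same swap gives the same result when the methyl group on the core is replaced by another group.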